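Swapping the Phenyl Substituent on a Triazole Nitrogen

The source may report more compounds than this note shows. Statements on the series, on what has been measured and on what is new or still open speak of the compounds shown alone.

In an ADME assay on L02 cells (Homo sapiens) for antiproliferative activity, read by MTT assay, with a stated time of 48 h (on this read-out lower numbers stand for stronger inhibition and higher numbers for weaker inhibition), compound 3 `COc1ccc(-n2nncc2CN2C(=O)C3(C(C#N)=C(N)Oc4c(N)cc5nc6ccccc6nc5c43)c3ccccc32)cc1` gives > 50000 nM, which is a limit of the assay rather than a number. Compound 1 `N#CC1=C(N)Oc2c(c3nc4ccccc4nc3c3ccccc23)C12C(=O)N(Cc1cnnn1-c1ccc(Br)cc1)c1ccccc12` likewise gives > 50000 nM in this assay, again a limit. Compound 2 `Cc1ccc(Cl)cc1-n1nncc1CN1C(=O)C2(C(C#N)=C(N)Oc3c2c2nc4ccccc4nc2c2ccccc32)c2ccccc21` gives > 50000 nM, also a limit. Among the compounds with values here, the only step between measured compounds that differ in one place, a step that the two limits leave unreadable from compound 1 to compound 2, cannot be sized: both of its ends share (the limit of > 50000 nM in this assay, at which 3 of the 3 values shown sit). Compound 4 `Cc1ccc(-n2nncc2CN2C(=O)C3(C(C#N)=C(N)Oc4c(N)cc5nc6ccccc6nc5c43)c3ccccc32)cc1Cl` has not yet been measured. It differs from compound 3 by 3-chloro-4-methylphenyl in place of 4-methoxyphenyl on an aromatic nitrogen. Within the data shown here, that change is of the same kind as the one between compound 1 and compound 2: one substituted phenyl on the aromatic nitrogen exchanged for another, here one carrying chlorine and methyl. Nothing in the three measured values, all of which share (the limit of > 50000 nM in this assay, at which 3 of the 3 values shown sit), points to a step beyond the scatter in either direction, and equally nothing rules one out. Compound 4 is therefore expected to give 60000 nM, within a range from 30000 nM to 150000 nM, and most likely to be reported once more as a limit. The step this estimate means, a step that the limit leaves unreadable from compound 3 to compound 4, is expected to be none beyond the scatter.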

Compound 4, half-maximal inhibitory concentration: > 50000 nM
Compound 4: a limit, no number; the forecaster's own chance of this, stated with the estimate: 85%; the middle value does not contradict the limit.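

In this assay compound 4 gives > 50000 nM, a limit of the assay and not a number. Within the data shown here, no step from compound 3 to compound 4 can be read, as both sit at one shared limit: the limit of > 50000 nM in this assay, at which 4 of the 4 values shown sit. The compounds shown leave open whether exchanging one substituted phenyl on the aromatic nitrogen for another changes the true value at all.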